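The compounds below may be only part of what the source reports. "The series", "measured", "known", "first", "only" and "open" are said of these compounds alone.

Compound 1 `CCCCNc1nc(N)nc2cccnc12` gives 1900 nM in an assay on tissue (PBMC cells) for agonist activity at Toll-like receptor 8 (Homo sapiens), with a stated time of 24 h; on this read-out lower numbers stand for an effect already at smaller amounts and higher numbers for an effect only at larger amounts of compound. Compound 2 `CCC[C@@H](CO)Nc1nc(N)nc2cccnc12` gives 430 nM in this assay, and a 4.4-fold lower number from compound 1 to compound 2 (0.65 log units; beyond the scatter). Compound 3 `CCCC[C@H](CN)Nc1nc(N)nc2cccnc12` gives 25000 nM in this assay, the highest of the three numbers: compound 1 is nearest to it and compound 2 furthest, both gaps beyond the scatter. Compound 4 `CCCC[C@@H](Nc1nc(N)nc2cccnc12)C(N)=O` is not yet measured in this assay. The change is carbamoyl in place of aminomethyl on a saturated chain carbon bound to a nitrogen on an aromatic ring and a saturated chain carbon. Among the measured compounds shown here, only the step from compound 1 to compound 2 touches the same chain carbon, and it swaps different groups, so it guides direction only loosely; no measured pair swaps aminomethyl for carbamoyl. A lowering is expected for compound 4, amounting to a 6.3-fold lower number from compound 3 to compound 4 (0.80 log units; beyond the scatter). Compound 4 is estimated at 4000 nM, with a range from 800 nM to 20000 nM.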

Compound 4, half-maximal effective concentration: 36000 nM
Compound 4: the middle estimate sits 9.0-fold (0.95 log units) below what was measured; the whole stated range lies below it.
By their numbers in this assay, from the lowest: compound 2; then compound 1; then compounds 3 and 4 (each within the scatter of the next).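

In this assay, carbamoyl in place of aminomethyl on this saturated chain carbon gives a 1.4-fold higher number from compound 3 to compound 4 (0.16 log units; within the scatter) and so leaves the number unmoved within the scatter. At this position, the two groups cannot be told apart by this read-out, unlike the hydroxymethyl step, a 4.4-fold lower number from compound 1 to compound 2 (0.65 log units; beyond the scatter). No available evidence accounts for this result. Still open, as far as these compounds go, is how a carboxylic acid or a methyl ester on this carbon would read, with the chain of compound 4 kept. Also open, from the compounds shown here alone, is whether hydroxymethyl on that same chain would keep the lower number of compound 2.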